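Chloro Added to a Series Resting at the Assay Limit

The source may report more compounds than this note shows. Statements on the series, on what has been measured and on what is new or still open speak of the compounds shown alone.

Of the compounds shown here, three have so far been tested in a functional assay on Bel-7402 cells (Homo sapiens) for cytotoxicity, read by MTT assay; on this read-out higher numbers stand for weaker inhibition and lower numbers for stronger inhibition. Compound 1 `COc1cc(/C=C/C(=O)c2sc(Nc3ccc(Cl)cc3)nc2C)cc(OC)c1OC` and compound 3 `COc1cc(/C=C/C(=O)c2sc(Nc3ccccc3)nc2C)cc(OC)c1OC` share one core, while compound 2 `Cc1nc(Nc2ccccc2)sc1C(=O)/C=C/c1ccccc1` carries a different core; the difference between the two cores is not broken down here.

In this assay compound 1 gives > 25000 nM, which is a limit of the assay and not a number. Compound 2 gives > 25000 nM, again a limit. Compound 3 gives > 25000 nM, also a limit.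

From compound 3 to compound 1 the change is chloro in place of hydrogen on an aromatic carbon. The step it made, a step that the two limits leave unreadable from compound 3 to compound 1, cannot be read because of the limit of > 25000 nM in this assay, at which 3 of the 3 values shown sit, so the two limits say nothing about whether the chloro helped or hurt.

Compound 4 `Cc1nc(Nc2ccccc2)sc1C(=O)/C=C/c1ccccc1Cl` has not been measured. It differs from compound 2 by chloro in place of hydrogen on an aromatic carbon. This is the same kind of change as that from compound 3 to compound 1, but the surroundings differ: in compound 4 the chloro enters ortho to a large group, whereas in compound 1 it sits para to a large group.

Compound 4 is expected to give about 30000 nM, within a range from 8000 nM to 100000 nM. The step expected from compound 2 to compound 4 is a step that the limit leaves unreadable from compound 2 to compound 4, an estimate that rests on compound 2 giving only the limit > 25000 nM and on the same kind of chloro change leaving the pair of compound 3 and compound 1 both at a limit.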

Compound 4, half-maximal inhibitory concentration: > 25000 nM
Compound 4: no number, only a limit (the forecaster's own chance of this, stated with the estimate: 80%); the middle value does not contradict the limit.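

Compound 4 gives > 25000 nM in this assay, which is a limit of the assay and not a number. No size can be given for the change from compound 2 to compound 4, phenyl to 2-chlorophenyl, because both compounds rest at the same limit: the limit of > 25000 nM in this assay, at which 4 of the 4 values shown sit. The compounds shown leave open whether chloro in place of hydrogen on an aromatic carbon changes the result in this assay at all, in either position.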